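The source may hold more compounds than are shown below. What is called first, only, known or untested is meant among the compounds shown, and "the series" means these compounds.

Working notes on the series

Compound 1 `NC[C@@H]1CCN(c2ccc3c(=O)c(C(=O)O)cn(Cc4ccc(-n5cccn5)cc4)c3c2)C1` and compound 2 `NC[C@@H]1CCN(c2ccc3c(=O)c(C(=O)O)cn(Cc4ccc(-c5ccccc5)cc4)c3c2)C1` share one core and differ only at one position. In an assay on isolated protein for inhibition of DNA topoisomerase 1 (Homo sapiens), with a stated time of 15 min (a higher number here means a weaker inhibitor, a lower number a stronger inhibitor), compound 1 gives 61000 nM, and compound 2 gives 61200 nM. The change between them is phenyl in place of 1H-pyrazol-1-yl on an aromatic carbon, and the step it made is a 1.0-fold higher number from compound 1 to compound 2 (0.00 log units; within the scatter). The two numbers therefore cannot be told apart.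

Compound 3 `O=C(O)c1cn(Cc2ccc(-n3cccn3)cc2)c2cc(NC[C@H]3CCNC3)c(F)cc2c1=O` rests on a different core; the difference between the core of compound 3 and the core of compound 1 is not broken down here. In this assay compound 3 gives 187000 nM, the highest of the three numbers, and its gap to both compound 1 and compound 2 lies beyond the scatter.

Compound 4 `O=C(O)c1cn(Cc2ccc(-c3ccccc3)cc2)c2cc(NC[C@H]3CCNC3)c(F)cc2c1=O` is the partner of compound 3 in the same change: phenyl in place of 1H-pyrazol-1-yl on an aromatic carbon. The place of the change reads the same for both pairs, so this is the same change already seen between compound 1 and compound 2. On the core of compound 1 that change left the number where it was, as shown by a 1.0-fold higher number from compound 1 to compound 2 (0.00 log units; within the scatter). For the measured compounds named here, the only guidance for the core of compound 3 is that single pair, so a flat step is expected here as well: no change at the digits printed from compound 3 to compound 4 (within the scatter) is the estimated step from compound 3 to compound 4 in this assay, and its reliance on one precedent on another core is a weakness. Compound 4 is expected to give 187000 nM in this assay, with a likely range from 90000 nM to 390000 nM.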

Compound 4, half-maximal inhibitory concentration: 100000 nM
Compound 4: the middle estimate sits 1.9-fold (0.27 log units) above what was measured, within the range that was stated.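

The exchange of 1H-pyrazol-1-yl for phenyl on compound 3 gives a 1.9-fold lower number from compound 3 to compound 4 (0.27 log units; within the scatter) in this assay, so the two numbers cannot be told apart. Set beside the earlier pair, the change carries from one core to the other with no difference that can be resolved: the same change on two cores in this assay, a 1.0-fold higher number (0.00 log units; within the scatter) from compound 1 to compound 2 and a 1.9-fold lower number (0.27 log units; within the scatter) from compound 3 to compound 4, 1.9-fold (0.27 log units) apart, within the scatter of two such steps

For the compounds shown here, this shows only that the two rings are interchangeable within the scatter on these two cores, in this one assay, with one pair on each core; it does not show that the exchange would behave the same way on any further core, nor that the position itself is indifferent to what stands there, as only these two rings have been compared.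

Open, going by these compounds, is how a group of another kind at the same place would read in this assay, for instance an amine, a carboxylic acid or a longer alkyl chain in place of the aromatic ring. Also open is which part of the difference between the core of compound 3 and the core of compound 1 bears on the numbers, as no compound shown separates those parts one at a time.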